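Replacing 2,4-dichlorophenyl with 2,4-difluorophenyl in a growth inhibitor

The compounds below may be only part of what the source reports. "The series", "measured", "known", "first", "only" and "open" are said of these compounds alone.

Of the compounds shown here, two that share one core have numbers so far in a functional assay on SK-OV-3 cells (Homo sapiens); a lower number here means a stronger inhibitor of growth, a higher number a weaker inhibitor of growth. Of these, compound 1 `O=S(=O)(/C=C/c1ccc(Br)cc1)Cc1ccc(Nc2ncnc3ccccc23)cc1` gives 1000 nM, and compound 2 `O=S(=O)(/C=C/c1ccc(Cl)cc1Cl)Cc1ccc(Nc2ncnc3ccccc23)cc1` gives 2000 nM. For the measured compounds named here, the one measured step, a 2.0-fold higher number from compound 1 to compound 2 (0.30 log units; within the scatter), lies within the scatter, so compound 2 does not stand apart from its only neighbour on these numbers.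

Compound 3 `O=S(=O)(/C=C/c1ccc(F)cc1F)Cc1ccc(Nc2ncnc3ccccc23)cc1` has not been measured. It differs from compound 2 as follows: 2,4-difluorophenyl in place of 2,4-dichlorophenyl on a double-bonded chain carbon bound to a double-bonded chain carbon. One bond further out, the same difference reads 2-(2,4-dichlorophenyl)ethenyl to 2-(2,4-difluorophenyl)ethenyl.

Going by the values given here, no measured step makes this exchange directly. Among the compounds with values here, the only evidence is the step at the same place on the chain, where 2,4-dichlorophenyl took the place of 4-bromophenyl. Since that step, a 2.0-fold higher number from compound 1 to compound 2 (0.30 log units; within the scatter), stayed within the scatter, no step beyond the scatter is expected in this assay, in either direction. The expected change is no change at the digits printed from compound 2 to compound 3 (within the scatter). Compound 3 is therefore estimated at 2000 nM, with an expected range of 700 nM to 6000 nM.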

Compound 3, concentration for 50% growth inhibition: 69000 nM
Estimate against measurement, compound 3: 35-fold (1.54 log units) below; measured number outside the range, above it.
By their numbers in this assay, from the lowest: compounds 1 and 2 (each within the scatter of the next); then compound 3.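

In this assay, the group on a double-bonded chain carbon bound to a double-bonded chain carbon proves far less forgiving than the first pair suggested: 2,4-difluorophenyl in place of 2,4-dichlorophenyl gives a 35-fold higher number from compound 2 to compound 3 (1.54 log units; beyond the scatter), and 2,4-difluorophenyl in place of 4-bromophenyl gives a 69-fold higher number from compound 1 to compound 3 (1.84 log units; beyond the scatter). The groups exchanged in the first of these steps have the same count of heavy atoms and the same ring of carbon only, with fluorine taking the place of chlorine, so an exchange of those two atoms alone is enough to produce a large step here, whereas the earlier step between the bromine and chlorine compounds stayed within the scatter. Nothing available on measured properties of these compounds accounts for the size of this step.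

The compounds shown leave open whether a single fluorine, as in 4-fluorophenyl, would already produce such a step, and whether an unsubstituted phenyl or 4-methoxyphenyl would fall with compounds 1 and 2 or with compound 3. They also leave open whether the exchange of chlorine for fluorine would have the same result on a different core.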